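A few compounds are considered here, and "the series" means these few. Any claim that something is new, unique, unknown or untested is made for them only; others in the source may bear on it.

In a functional assay on MDA-MB-231 cells (Homo sapiens) for antiproliferative activity, read by sulforhodamine B assay, with a stated time of 72 h (a higher number here means a weaker inhibitor, a lower number a stronger inhibitor), compound 1 (`O=C(/C=C/c1cc2ccccc2s1)c1cc(Cl)ccc1O`) gives > 10000 nM as a limit of the assay and not a number. Compound 2 (`O=C(/C=C/c1cc2ccccc2s1)c1cc(Br)ccc1O`) gives > 10000 nM as a limit too. The evidence so far is the limit of > 10000 nM in this assay, at which 2 of the 2 values shown sit, and nothing more, so compound 1 has no readable standing. For the measured compounds named here, the only measured step is a step that the two limits leave unreadable from compound 1 to compound 2 and it offers no size to carry over. Compound 3 (`O=C(/C=C/c1cc2ccccc2s1)c1cc(Cl)cc(Cl)c1O`) carries chloro in place of hydrogen on an aromatic carbon as its change from compound 1, chloro in place of hydrogen on an aromatic carbon, ortho to a hydroxy group and meta to a chloro group. Going by the values given here, no measured step covers this change, so no step of known size or direction is expected in this assay beyond the scatter. For compound 3 the estimated value is 15000 nM with 4000 nM to 40000 nM as the expected range. This means an expected step that the limit leaves unreadable from compound 1 to compound 3 and it remains only an estimate.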

Compound 3, half-maximal inhibitory concentration: 7500 nM
For compound 3 the middle estimate is 2.0-fold (0.30 log units) above the measured one, within the range that was stated.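

Chloro in place of hydrogen on this aromatic carbon, ortho to a hydroxy group and meta to a chloro group, gives in this assay an at least 1.3-fold lower number from compound 1 to compound 3 (0.12 log units; that floor lies within the scatter). For the compounds shown here, compound 3 is thus the first compound here with a readable number rather than a limit, so this position can carry a second chloro group without the value staying out of reach. Even so, the step has only a floor, and its true size cannot be read, as the comparison rests on a limit: the limit of > 10000 nM in this assay, at which 2 of the 3 values shown sit.

The compounds shown leave open how far compound 1 really lies from compound 3. They also leave open what bromo, methyl, an amine or a carboxylic acid on this same aromatic carbon would give in this assay.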